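Adding a propargyloxy group to compound 2

The source may hold more compounds than are shown below. What is called first, only, known or untested is meant among the compounds shown, and "the series" means these compounds.

Of the compounds shown here, two sharing one core have numbers so far. In a functional assay on the whole organism for inhibition, with Scenedesmus acutus as the target, with a stated time of 20 h (on this read-out lower numbers stand for stronger inhibition and higher numbers for weaker inhibition), compound 1 `C#CCOc1cc(N2C(=O)C3=C(CCCC3)C2=O)ccc1Cl` gives 501 nM and compound 2 `O=C1C2=C(CCCC2)C(=O)N1c1ccc(Cl)cc1F` gives 251 nM as its result. These two numbers lie within the usual scatter of each other, so the pair cannot be ranked.

The next molecule, compound 3 `C#CCOc1cc(N2C(=O)C3=C(CCCC3)C2=O)c(F)cc1Cl`, starts from compound 2 and makes one change: propargyloxy in place of hydrogen on an aromatic carbon with propargyloxy in place of hydrogen on an aromatic carbon, ortho to the chloro group and para to the fluoro group.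

Among the compounds with values here, no measured pair isolates this change, so its size can only be judged indirectly. Compound 1 carries propargyloxy without the fluoro group and reaches 501 nM in that form, while compound 2 carries the fluoro group without propargyloxy and reaches 251 nM in that form. Compound 3 holds both groups, so a move toward stronger inhibition, beyond the scatter, is expected in this assay here. The estimated change is a 5.0-fold lower number from compound 2 to compound 3 (0.70 log units; beyond the scatter) on this reasoning. For compound 3 the expected value is 50 nM with an estimated range from 10 nM to 250 nM for the measurement.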

Compound 3, half-maximal inhibitory concentration: 126 nM
The estimate for compound 3 lay 2.5-fold (0.40 log units) below the measured number; the measured number falls inside the stated range.
By their numbers in this assay, from the lowest: compounds 3, 2 and 1 (each within the scatter of the next, the first and the last beyond it).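

With propargyloxy in place of hydrogen on an aromatic carbon, ortho to a chloro group and para to a fluoro group, this assay gives a 2.0-fold lower number from compound 2 to compound 3 (0.30 log units; within the scatter), so adding this group to compound 2 produces no change that can be told apart from the scatter. Compound 1 and compound 3 differ only by fluoro in place of hydrogen on an aromatic carbon, and here the data give a 4.0-fold lower number from compound 1 to compound 3 (0.60 log units; beyond the scatter), a modest step but one that lies beyond the scatter, so with propargyloxy present the fluoro group makes a readable difference in this assay. Nothing measured here explains why either step has the size it has.

On these data alone, it remains open whether a smaller group such as methoxy, a longer chain such as butynyloxy, or an amine at this same position would move the number clear of the scatter from compound 2. As far as these compounds go, it is also open whether the fluoro step would keep its size with hydrogen in place of propargyloxy, a comparison these three compounds cannot make.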